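The source may hold more compounds than are shown below. What is called first, only, known or untested is meant among the compounds shown, and "the series" means these compounds.

Compound 1 `CNC(=O)c1cc(Oc2ccc(NC(=O)c3cc(-c4ccc(OC)cc4)ncn3)cc2F)ccn1` is the reference point of this small set. In a functional assay on MCF7 cells (Homo sapiens) for cytotoxicity, read by MTT assay, with a stated time of 72 h (on this read-out higher numbers stand for weaker inhibition and lower numbers for stronger inhibition), compound 1 gives 46200 nM, the highest of the two numbers shown; compound 3 `CNC(=O)c1cc(Oc2ccc(NC(=O)c3cc(-c4ccccc4)ncn3)cc2F)ccn1` gives 32400 nM, and the gap between the two stays within the scatter, so neither is ranked above the other. Compound 2 `CNC(=O)c1cc(Oc2ccc(NC(=O)c3cc(-c4ccc(Br)cc4)ncn3)cc2F)ccn1` reaches only the limit of the assay, > 100000 nM (the limit of > 100000 nM in this assay, at which 1 of the 3 values shown sits). The three measured steps all replace one substituent on an aromatic carbon in another part of the molecule: an at least 2.1-fold higher number from compound 1 to compound 2 (0.33 log units; beyond the scatter), a 1.4-fold lower number from compound 1 to compound 3 (0.15 log units; within the scatter) and an at least 3.0-fold lower number from compound 2 to compound 3 (0.48 log units; beyond the scatter). Compound 4 `CNC(=O)c1cc(Oc2ccc(NC(=O)c3cc(-c4ccc(OC)cc4)ncn3)cc2)ccn1` differs from compound 1 at a different place: hydrogen in place of fluoro on an aromatic carbon. Within the data shown here, none of the measured steps touches that position, so they offer no direct guide to the size or direction of this change. The expectation is therefore a step that stays within the scatter, a 1.0-fold lower number from compound 1 to compound 4 (0.00 log units; within the scatter). Compound 4 is estimated at 46000 nM in this assay, with a range from 20000 nM to 105000 nM. Since one compound of the set already sits at the limit, a reading that again comes back only as a limit cannot be ruled out for compound 4.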

Compound 4, half-maximal inhibitory concentration: 29200 nM
Estimate against measurement, compound 4: 1.6-fold (0.20 log units) above; measured number inside the range.
By their numbers in this assay, from the lowest: compounds 4, 3 and 1 (each within the scatter of the next). At a limit, above all of these: compound 2.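

In this assay, hydrogen in place of fluoro on the aromatic carbon ortho to the (2-(methylcarbamoyl)pyridin-4-yl)oxy group gives a 1.6-fold lower number from compound 1 to compound 4 (0.20 log units; within the scatter). Among these compounds, this is the first reading at this position, as all earlier steps lay in another part of the molecule, and it shows that with the methoxy group in place the fluoro can be exchanged for hydrogen without a change beyond the scatter, so the fluoro is not required for the activity of compound 1 on these cells. Nothing among the data shown bears on why this step has the size it has.

Whether the exchange stays this small on other backgrounds is open, in particular with the bromo of compound 2, the only substituent so far to shift the reading beyond the scatter, or with the unsubstituted ring of compound 3. Also open is how the reading responds to a different group on this same carbon, such as chloro, methyl or an amine, since hydrogen is the only replacement for fluoro shown here.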